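The source may hold more compounds than are shown below. What is called first, only, known or untested is meant among the compounds shown, and "the series" means these compounds.

Measured compounds:
- compound 1, `COc1ccc(S(=O)(=O)N2CC(C(=O)N(C)C3CCN(C)CC3)c3ccccc32)c2ccccc12`, gives 7.94 nM
- compound 2, `COc1ccc(S(=O)(=O)N2CC(C(=O)N3CC(N)C3)c3ccccc32)c2ccccc12`, gives 158 nM
- compound 3, `CCN(CC)CCNC(=O)C1CN(S(=O)(=O)c2ccc(OC)c3ccccc23)c2ccccc21`, gives 20 nM

All three were tested in a functional assay on CHO cells for antagonist activity at 5-hydroxytryptamine receptor 6 (Homo sapiens), read by FLIPR; on this read-out lower numbers stand for stronger inhibition and higher numbers for weaker inhibition. Compound 1 has the lowest number of the three. Its nearest neighbour is compound 3, with a 2.5-fold higher number from compound 1 to compound 3 (0.40 log units; beyond the scatter), and the furthest is compound 2, with a 20-fold higher number from compound 1 to compound 2 (1.30 log units; beyond the scatter). Between the other two lies a 7.9-fold lower number from compound 2 to compound 3 (0.90 log units; beyond the scatter). Each of these steps changes only the group attached to the carbonyl carbon of the amide, while the rest of the shared core stays the same.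

Compound 4, `CN1CCC(N(C)C(=O)C2CN(S(=O)(=O)c3cccc4ccccc34)c3ccccc32)CC1`, has not yet been tested. It keeps the amide group of compound 1 and differs from it at a single point: hydrogen in place of methoxy on an aromatic carbon. For the measured compounds named here, none of the measured steps touches this part of the molecule, so there is no direct guide to the size or direction of the change. What the three measured compounds do show is that the shared core tolerates several different amide groups while staying within a fairly narrow band of numbers.

Lacking a directly comparable step, a modest rise in the number is expected for compound 4, with a wide range: 25 nM, between 6 nM and 100 nM, which would amount to an expected step of a 3.1-fold higher number from compound 1 to compound 4 (0.50 log units; beyond the scatter).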

Compound 4, inhibition constant: 31.6 nM
Compound 4: the middle estimate sits 1.3-fold (0.10 log units) below what was measured, and the stated range covers the measured number.
By their numbers in this assay, from the lowest: compound 1; then compounds 3 and 4 (each within the scatter of the next); then compound 2.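

In this assay, replacing the methoxy with hydrogen gives a 4.0-fold higher number from compound 1 to compound 4 (0.60 log units; beyond the scatter), the first sign that a site outside the amide group also affects the number. The methoxy, para to a large group on the aromatic ring, therefore contributes to the low number of compound 1, but removing it still costs less than the largest amide change, a 20-fold higher number from compound 1 to compound 2 (1.30 log units; beyond the scatter). Nothing available explains why the number rises when the methoxy is lost.

The compounds shown place only methoxy and hydrogen at this position, so it remains open whether an ethoxy group, a hydroxyl group or a chlorine atom would give a number closer to that of compound 1, or a lower one. For the compounds shown here, it is also open whether the same change would have a similar effect alongside the 3-aminoazetidin-1-yl group of compound 2 or the (2-(diethylamino)ethyl)amino group of compound 3, since the only pair that isolates it carries the methyl(1-methylpiperidin-4-yl)amino group.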